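A few compounds are considered here, and "the series" means these few. Any claim that something is new, unique, unknown or untested is made for them only; others in the source may bear on it.

Compound 1, `C=CCNC(=O)n1c(-c2ccc(OC)cc2)cc(=O)c2c(OC)cc(OC)cc21`, gives 16000 nM in a functional assay on SUP-B15 cells (Homo sapiens) for antiproliferative activity, with a stated time of 72 h; on this read-out higher numbers stand for an effect only at larger amounts of compound and lower numbers for an effect already at smaller amounts.
Compound 2, `COc1ccc(-c2c(Cl)c(=O)c3c(OC)cc(OC)cc3n2S(=O)(=O)c2ccc(OC)cc2)cc1`, gives 17900 nM in this assay.
Compound 3, `COC(=O)c1cc(=O)c2cc(N)ccc2[nH]1`, gives only a limit in this assay, namely > 67200 nM.

Two of the three compounds thus give a number in this assay, and compound 1 stands within the scatter of compound 2, so the two cannot be told apart. Compound 3 is recorded only as a limit, as stated in the limit of > 67200 nM in this assay, at which 1 of the 3 values shown sits.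

The account follows the step from compound 1 to the not yet measured compound 4, `COc1ccc(-c2cc(=O)c3c(OC)cc(OC)cc3n2S(=O)(=O)c2cccc(Br)c2)cc1`. The change is (3-bromophenyl)sulfonyl in place of allylcarbamoyl on an aromatic nitrogen. After this change the nitrogen of the shared core carries the (3-bromophenyl)sulfonyl group, as compound 2 carries a sulfonyl group on the same nitrogen. Compound 2 gives 17900 nM, close to compound 1, which suggests that the sulfonyl group alone does not move the number beyond the scatter. Compound 4 is therefore expected to give 15000 nM in this assay, within a range of 5000 nM to 45000 nM. The step of a 1.1-fold lower number from compound 1 to compound 4 (0.03 log units; within the scatter) is expected to remain within the scatter, in no clear direction.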

Compound 4, half-maximal effective concentration: > 58600 nM
Compound 4 gave a limit, no number; the forecaster's own chance of this, stated with the estimate: 15%; at least 3.9-fold (0.59 log units) between middle value and limit.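

In this assay, going by these compounds alone, the exchange at this aromatic nitrogen gives an at least 3.6-fold higher number from compound 1 to compound 4 (0.56 log units; beyond the scatter) and so, unlike anything the earlier compounds offered, shows that this position does respond to the group it carries. Compound 2 also bears a sulfonyl group on this nitrogen and gives 17900 nM in this assay, so a sulfonyl group there can go with a measured number, although compound 2 differs from compound 4 in more than one place. The reading for compound 4 is itself a limit and not a number: the limit of > 58600 nM in this assay, at which 1 of the 4 values shown sits.

The compounds shown leave open whether the sulfonyl link or the 3-bromophenyl ring goes with the higher number, and how far compound 4 lies past its limit. A methylsulfonyl group, or a longer chain in place of the allyl on the carbamoyl group, would bear on this.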